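A few compounds are considered here, and "the series" means these few. Any claim that something is new, unique, unknown or untested is made for them only; others in the source may bear on it.

Compound 2, with the structure `CO[C@@H]1[C@H](N(C)c2ncc(-c3c[nH]c4ccc(F)cc34)s2)C[C@H]2O[C@]1(C)n1c3ccccc3c3c4c(c5c6cc(Cl)ccc6n2c5c31)C(=O)NC4`, was examined in an ADME assay on PBMC cells (Homo sapiens) for cytotoxicity, read by CellTiter-Glo, with a stated time of 72 h; on this read-out lower numbers stand for stronger inhibition and higher numbers for weaker inhibition. In this assay compound 2 gives only a limit of the test, > 10000 nM, and not a measured number. The other compound shown, compound 1, with the structure `CO[C@@H]1[C@H](N(C)c2ncc(-c3c[nH]c4ccc(Br)cc34)s2)C[C@H]2O[C@]1(C)n1c3ccccc3c3c4c(c5c6ccccc6n2c5c31)C(=O)NC4`, likewise returns only a limit in this assay, > 10000 nM. Both results therefore sit at the same ceiling, namely (the limit of > 10000 nM in this assay, at which 2 of the 2 values shown sit), so the two values show no difference between compound 1 and compound 2 in this assay; they place compound 2 at the weak end of what the test can report.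

The next compound, compound 3, has the structure `CO[C@@H]1[C@H](N(C)c2ncc(-c3c[nH]c4ccc(Br)cc34)s2)C[C@H]2O[C@]1(C)n1c3ccccc3c3c4c(c5c6cc(Cl)ccc6n2c5c31)C(=O)NC4`. It differs from compound 2 by bromo in place of fluoro on an aromatic carbon. Within the data shown here, no measured step between two compounds that differ in one place is available, so no size can be read from the data. The account expects the step from compound 2 to compound 3 in this assay to be a step that the limit leaves unreadable from compound 2 to compound 3, which is to say no change beyond the scatter. On that basis compound 3 is estimated at 15000 nM, within a range from 5000 nM to 50000 nM, and most likely it too will return only a limit.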

Compound 3, half-maximal inhibitory concentration: > 10000 nM
Compound 3 gave a limit, no number; the forecaster's own chance of this, stated with the estimate: 85%; the middle value lies beyond the limit too.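

Compound 3 also returns only a limit in this assay, so the steps linking it to compound 1 and to compound 2 cannot be read, and all three compounds rest at the same ceiling: the limit of > 10000 nM in this assay, at which 3 of the 3 values shown sit. The compounds shown leave open where any of them would fall past that limit, and whether either exchange, bromo for fluoro or chloro for hydrogen, alters the read-out at all.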